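Ethoxy for Vinyl: Cytotoxicity Expected Largely to Hold

The source may hold more compounds than are shown below. What is called first, only, known or untested is meant among the compounds shown, and "the series" means these compounds.

Two measured compounds share one core and differ only in a small side group on a five-membered aromatic ring. Compound 1 `CCc1ccc(CN[C@@H]2C[C@H]3C[C@@H]([C@H]2C)C3(C)C)s1` in an ADME assay on MDCK cells (Canis lupus familiaris) for cytotoxicity, read by microscopy, with a stated time of 48 h (on this read-out lower numbers stand for higher toxicity in this test and higher numbers for lower toxicity in this test), gives 1560 nM. Compound 2 `C=Cc1ccsc1CN[C@@H]1C[C@H]2C[C@@H]([C@H]1C)C2(C)C` in this assay gives 50000 nM. Of the two numbers, compound 2 stands highest, and its gap to compound 1 lies well beyond the scatter of repeat tests, so compound 2 is the less toxic of the pair. Compound 3 `CCOc1ccsc1CN[C@@H]1C[C@H]2C[C@@H]([C@H]1C)C2(C)C` has not been tested yet. It differs from compound 2 by ethoxy in place of vinyl on an aromatic carbon. For the measured compounds named here, no measured step shows how such a change acts here; the two values at hand show only that a small change on this ring can move the number far. A step of a 2.0-fold lower number from compound 2 to compound 3 (0.30 log units; within the scatter) is expected, modest and toward a lower number. Compound 3 is therefore estimated at 25000 nM, within a range from 5000 nM to 50000 nM.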

Compound 3, minimum cytotoxic concentration: 50000 nM
The estimate for compound 3 lay 2.0-fold (0.30 log units) below the measured number; the measured number falls inside the stated range.
By their numbers in this assay, from the lowest: compound 1; then compounds 2 and 3 (each within the scatter of the next).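

In this assay, putting ethoxy in place of vinyl on an aromatic carbon, two ring bonds from the ring sulfur, gives no change at the digits printed from compound 2 to compound 3 (within the scatter). For the compounds shown here, this is the first measured step at this position, and it shows that the swap, which adds one hydrogen-bond acceptor and removes the double bond outside the aromatic ring, leaves the read-out within the scatter. Nothing measured here explains why the two groups read alike.

Going by these compounds, whether an amine, a carboxylic acid or a longer chain such as butoxy would also leave the number unmoved at this position remains open. So does whether the same swap would give the same result at another carbon of this ring.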